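Fluorine position on the aryl group: compound 3

The source may report more compounds than this note shows. Statements on the series, on what has been measured and on what is new or still open speak of the compounds shown alone.

Compound 1 `Cc1ccc2c(C3CCN(CCN4CCN(C(C)C)C4=O)CC3)cn(-c3ccc(F)cc3)c2c1` gives 85 nM in an assay on cell membranes for displacement of a labelled ligand from Adrenergic receptor alpha-1 (Rattus norvegicus); a lower number here means a stronger inhibitor, a higher number a weaker inhibitor. Compound 2 `Cc1ccc2c(C3CCN(CCN4CCN(C(C)C)C4=O)CC3)cn(-c3ccccc3F)c2c1` gives 370 nM in this assay. Compound 2 stands at the highest number of the two measured compounds; its nearest neighbour is compound 1, and the step between them, a 4.4-fold higher number from compound 1 to compound 2 (0.64 log units; beyond the scatter), lies beyond the scatter. Compound 3 `Cc1ccc2c(C3CCN(CCN4CCN(C(C)C)C4=O)CC3)cn(-c3cccc(F)c3)c2c1` is not yet measured in this assay.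

The change from compound 2 to compound 3 is 3-fluorophenyl in place of 2-fluorophenyl on an aromatic nitrogen. Within the data shown here, the only measured step that bears on it is a 4.4-fold higher number from compound 1 to compound 2 (0.64 log units; beyond the scatter), which moves the fluorine on the same aryl group and produced a modest rise in the number. Among the measured compounds shown here, compound 3 carries the fluorine at a third position on that ring, for which no step is known; the new position is therefore placed between the two measured ones rather than at either end. The expected step is a 2.1-fold lower number from compound 2 to compound 3 (0.31 log units; beyond the scatter), a modest fall below compound 2 but not all the way back to compound 1. The estimate for compound 3 in this assay is 180 nM, with a range from 60 nM to 550 nM.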

Compound 3, half-maximal inhibitory concentration: 670 nM
Compound 3: the middle estimate sits 3.7-fold (0.57 log units) below what was measured; the whole stated range lies below it.
By their numbers in this assay, from the lowest: compound 1; then compounds 2 and 3 (each within the scatter of the next).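

With 3-fluorophenyl in place of 4-fluorophenyl on the aromatic nitrogen, this assay shows a 7.9-fold higher number from compound 1 to compound 3 (0.90 log units; beyond the scatter) and this sets compound 1 apart from a second isomer, not only from the 2-fluorophenyl compound. The other new comparison, a 1.8-fold higher number from compound 2 to compound 3 (0.26 log units; within the scatter), does not separate 2-fluorophenyl from 3-fluorophenyl, so the three fluorine placements do not form a graded order: they fall into compound 1 on one side and compounds 2 and 3 together on the other, and within this small set only the 4-fluorophenyl group stands out. No measurement at hand accounts for this difference between the isomers.

From the compounds shown here alone, whether a plain phenyl, 4-chlorophenyl or 4-methoxyphenyl group on the aromatic nitrogen would match compound 1 or fall with compounds 2 and 3 remains open, and with it whether the effect is specific to fluorine. Also open, going by these compounds, is whether the same split among the fluorophenyl isomers would hold with a chlorine atom in place of the methyl group on the shared core.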